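Swapping the Aryl Group on the Sulfur-Bound Carbon

The source may hold more compounds than are shown below. What is called first, only, known or untested is meant among the compounds shown, and "the series" means these compounds.

Three compounds share one core and differ only in the aryl group on the saturated chain carbon bound to a sulfur. Compound 1 `c1ccc(CSc2nnc(-c3ccc4c(c3)OCCO4)n2-c2ccccc2)cc1` gives 7930 nM in a functional assay on SW 1116 cells (Homo sapiens) for antiproliferative activity, read by MTT assay, with a stated time of 24 h; on this read-out higher numbers stand for weaker inhibition and lower numbers for stronger inhibition. Compound 2 `O=[N+]([O-])c1ccc(CSc2nnc(-c3ccc4c(c3)OCCO4)n2-c2ccccc2)cc1` gives 13800 nM in this assay, and compound 3 `Clc1cccc(CSc2nnc(-c3ccc4c(c3)OCCO4)n2-c2ccccc2)c1` gives 10600 nM. Compound 3 stands second highest of the three numbers, yet all three lie within the scatter of one another, as the steps of a 1.3-fold higher number from compound 1 to compound 3 (0.13 log units; within the scatter) and a 1.3-fold lower number from compound 2 to compound 3 (0.11 log units; within the scatter) show. Compound 4 `Brc1ccccc1CSc1nnc(-c2ccc3c(c2)OCCO3)n1-c1ccccc1` differs from compound 3 by 2-bromophenyl in place of 3-chlorophenyl on a saturated chain carbon bound to a sulfur. The step of a 1.3-fold lower number from compound 2 to compound 3 (0.11 log units; within the scatter) bears most directly on this change, and a 1.7-fold higher number from compound 1 to compound 2 (0.24 log units; within the scatter) adds nothing beyond the scatter either. No step beyond the scatter is therefore expected in this assay. The expected step is a 1.1-fold lower number from compound 3 to compound 4 (0.03 log units; within the scatter). Compound 4 is estimated at 10000 nM, between 5000 nM and 22000 nM.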

Compound 4, half-maximal inhibitory concentration: 7350 nM
For compound 4 the middle estimate is 1.4-fold (0.13 log units) above the measured one, and the stated range covers the measured number.
By their numbers in this assay, from the lowest: compounds 4, 1, 3 and 2 (each within the scatter of the next).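

With 2-bromophenyl at this position, the number in this assay shows no step beyond the scatter against any earlier compound (a 1.4-fold lower number from compound 3 to compound 4 (0.16 log units; within the scatter)), (a 1.9-fold lower number from compound 2 to compound 4 (0.27 log units; within the scatter)), (a 1.1-fold lower number from compound 1 to compound 4 (0.03 log units; within the scatter)). Bromo thus joins nitro and chloro as a third aromatic substituent that leaves this read-out within the scatter of the unsubstituted compound 1. Nothing available explains why these numbers stay so close. As far as these compounds go, it remains open whether an amine or a carboxylic acid on this aromatic ring would produce a step beyond the scatter. The same holds for a longer chain in place of the saturated chain carbon bound to a sulfur.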